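Methyl in place of chloro: compound 1 to compound 3

The compounds below may be only part of what the source reports. "The series", "measured", "known", "first", "only" and "open" are said of these compounds alone.

compound 1: `CS(=O)(=O)c1ccc(Cl)cc1NCC1=NCCN1` — < 6310 nM
compound 2: `COc1ccc(SC)c(NCC2=NCCN2)c1` — < 6310 nM

In an assay on CHO cells for binding affinity to Alpha-2B adrenergic receptor (Homo sapiens), read by radioligand binding (a lower number here means a stronger inhibitor, a higher number a weaker inhibitor), compound 1 gives < 6310 nM, which is a limit rather than a number. Compound 2 gives < 6310 nM in this assay, also a limit. Compound 1 therefore stands at the limit of < 6310 nM in this assay, at which 2 of the 2 values shown sit, with no numeric value to place it against anything. Compound 3, `Cc1ccc(S(C)(=O)=O)c(NCC2=NCCN2)c1`, differs from compound 1 by methyl in place of chloro on an aromatic carbon. Among the measured compounds shown here, no measured step connects the two; the expectation is a step in this assay within the scatter, in no particular direction. Compound 3 is estimated at 1500 nM, with a range from 150 nM to 6310 nM. The step that the limit leaves unreadable from compound 1 to compound 3 is expected to be small.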

Compound 3, inhibition constant: < 6310 nM
Compound 3: a limit, no number; the forecaster's own chance of this, stated with the estimate: 65%; the middle value lies beyond the limit too.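

Compound 1 and compound 3 both stand as limits in this assay, so no step between them can be read: the limit of < 6310 nM in this assay, at which 3 of the 3 values shown sit.

The compounds shown leave open whether methyl in place of chloro on an aromatic carbon shifts the inhibition constant at all, and in which direction.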